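The compounds below may be only part of what the source reports. "The series", "measured", "known", "first", "only" and "open" are said of these compounds alone.

Compound 1 `CCCNS(=O)(=O)c1ccc(Nc2ncc3c(n2)N(C2CCCC2)[C@H](CC)C(=O)N3C)cc1` and compound 2 `CC[C@@H]1C(=O)N(C)c2cnc(Nc3ccc(S(N)(=O)=O)cc3)nc2N1C1CCCC1` share a core with compound 3 `CC[C@@H]1C(=O)N(C)c2cnc(-n3ccc4cc(C(=O)NCC(C)C)ccc43)nc2N1C1CCCC1`, but the first two carry a sulfonamide-bearing aniline where compound 3 carries an indole with an amide. Among the compounds with values here, in a functional assay on Huh-7 cells (Homo sapiens) for antiproliferative activity, read by CCK-8 assay, with a stated time of 72 h (a lower number here means a stronger inhibitor of growth, a higher number a weaker inhibitor of growth), compound 1 gives 278 nM and compound 2 gives 1300 nM; the one recorded step, a 4.7-fold higher number from compound 1 to compound 2 (0.67 log units; beyond the scatter), lies at the sulfonamide nitrogen and so does not touch the part that changes here. Compound 3 itself is reported in this assay as "not active" (no number reported), with no number attached, so it stands apart from the two compounds that gave values.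

Compound 4 `CCCCNC(=O)c1ccc2c(ccn2-c2ncc3c(n2)N(C2CCCC2)[C@H](CC)C(=O)N3C)c1` is built from the same atoms as compound 3, joined differently: propyl in place of isopropyl on a saturated chain carbon bound to an amide-type nitrogen, which one bond further out reads isobutylcarbamoyl to butylcarbamoyl. Within the data shown here, no measured step bears directly on this change. With compound 3 inactive and the core and indole kept, the expectation is that compound 4 also shows little activity in this assay, most likely reported again without a number. Compound 4 is estimated at 30000 nM, within a range from 5000 nM to 200000 nM.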

Compound 4, concentration for 50% growth inhibition: 683 nM
Estimate against measurement, compound 4: 44-fold (1.64 log units) above; the whole stated range lies above it.
By their numbers in this assay, from the lowest: compound 1; then compounds 4 and 2 (each within the scatter of the next).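

Compound 3 has no number in this assay, while compound 4 gives 683 nM, so no new step can be read between them. No measured evidence accounts for this result. The compounds shown leave open how other amide chains on the indole would perform.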